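The compounds below may be only part of what the source reports. "The series", "measured", "known", "first", "only" and "open" are said of these compounds alone.

Going by the values given here, in a functional assay on NCI-H226 cells (Homo sapiens) for inhibition, read by sulforhodamine B assay, with a stated time of 48 h (on this read-out higher numbers stand for weaker inhibition of growth and lower numbers for stronger inhibition of growth), compound 3 (`COc1cc(-c2nn(-c3cccc(NC(=O)c4ccc(Cl)c(C(F)(F)F)c4)c3)cc2-c2ccncc2)ccc1Cl`) gives 5900 nM as the highest of the three numbers so far. Compound 1 (`COc1cc(-c2nn(-c3cccc(NC(=O)c4cccc(C(F)(F)F)c4)c3)cc2-c2ccncc2)ccc1Cl`) gives 1660 nM and compound 2 (`COc1cc(-c2nn(-c3cccc(NC(=O)Nc4ccc(Cl)c(Cl)c4)c3)cc2-c2ccncc2)ccc1Cl`) gives 1350 nM on the same read-out, and these two lie within the scatter of each other (a 1.2-fold lower number from compound 1 to compound 2 (0.09 log units; within the scatter)).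

The next compound, compound 4 (`COc1cc(-c2nn(-c3cccc(NC(=O)c4ccccc4)c3)cc2-c2ccncc2)ccc1Cl`), has phenyl in place of 4-chloro-3-(trifluoromethyl)phenyl on a carbonyl carbon. The most direct evidence is the measured step for chloro in place of hydrogen on an aromatic carbon (a 3.6-fold higher number from compound 1 to compound 3 (0.55 log units; beyond the scatter)), and the present change removes that chloro along with the trifluoromethyl. This step suggests a move toward a lower number. Among the compounds with values here, the data hold no step for removing the trifluoromethyl alone, so that part of the change stays open and widens the range. The step that replaces (3,4-dichlorophenyl)amino (a 4.4-fold higher number from compound 2 to compound 3 (0.64 log units; beyond the scatter)) also changes the atom on the carbonyl carbon, so it bears only loosely on this change.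

A modest step toward a lower number is therefore expected in this assay (a 2.4-fold lower number from compound 3 to compound 4 (0.37 log units; beyond the scatter)). For compound 4 the estimated value is 2500 nM (expected range 900 nM to 7000 nM).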

Compound 4, concentration for 50% growth inhibition: 2350 nM
Estimate against measurement, compound 4: 1.1-fold (0.03 log units) above; measured number inside the range.
By their numbers in this assay, from the lowest: compounds 2, 1 and 4 (each within the scatter of the next); then compound 3.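

In this assay, removing both substituents gives a step beyond the scatter (a 2.5-fold lower number from compound 3 to compound 4 (0.40 log units; beyond the scatter)), whereas removing the trifluoromethyl alone stays within it (a 1.4-fold higher number from compound 1 to compound 4 (0.15 log units; within the scatter)), so on the phenyl on this carbonyl carbon the trifluoromethyl shows no readable effect when no chloro is present. Among these amides, the only steps beyond the scatter are those to or from compound 3, the one compound that carries 4-chloro-3-(trifluoromethyl)phenyl, which fits the earlier chloro step (a 3.6-fold higher number from compound 1 to compound 3 (0.55 log units; beyond the scatter)); the plain phenyl also stays within the scatter of the (3,4-dichlorophenyl)amino compound (a 1.7-fold higher number from compound 2 to compound 4 (0.24 log units; within the scatter)), so the simple amide and this urea-type compound cannot be separated here. No measurement at hand explains any of these steps.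

The compounds shown leave open whether a chloro on this phenyl without the trifluoromethyl would give a number like that of compound 3 or one like that of compound 4. They also leave open how a basic amine or a carboxylic acid on this phenyl would read out on the same scale.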